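Methoxy for chloro on the pyridyl ring: clearance outlook

This account rests on a few compounds, and the source may have more. Where it says the series, first, only, none or still open, it means among the compounds named here.

Compound 1 `Cc1nc2cnc(C(=O)NC3CN(c4cc(Cl)ncc4Cl)C3)cn2c1C` and compound 2 `Cc1nn(C)c2cnc(C(=O)NC3CN(c4cc(Cl)ncc4Cl)C3)cc12` have been run in an ADME assay on microsomes (Rattus norvegicus) for metabolic stability; on this read-out higher numbers stand for fast clearance and lower numbers for slow clearance. Compound 1 gives 96 mL/min/kg; compound 2 gives 85 mL/min/kg. The two numbers lie within the scatter of each other, so no order between them can be read from them. Compound 3 `COc1cc(N2CC(NC(=O)c3cn4c(C)c(C)nc4cn3)C2)c(Cl)cn1` is not yet measured in this assay. It differs from compound 1 by methoxy in place of chloro on an aromatic carbon. Among the measured compounds shown here, with no measured step of this kind to lean on, no change beyond the scatter is expected in this assay: the expected step is a 1.1-fold lower number from compound 1 to compound 3 (0.03 log units; within the scatter). Compound 3 is therefore estimated at 90 mL/min/kg, within 50 mL/min/kg to 160 mL/min/kg.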

Compound 3, clearance: 83 mL/min/kg
Compound 3: middle estimate off by 1.1-fold (0.04 log units), on the high side; measured number inside the range.
By their numbers in this assay, from the lowest: compounds 3, 2 and 1 (each within the scatter of the next).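

In this assay, the first step read at this position, methoxy in place of chloro next to the ring nitrogen, gives a 1.2-fold lower number from compound 1 to compound 3 (0.06 log units; within the scatter). At this position, then, this change does not separate compound 3 from compound 1 beyond the scatter. No measurement here speaks to the mechanism of clearance in these compounds. As far as these compounds go, whether an amine or a longer chain at this position would move the number beyond the scatter stays open. So does whether methoxy in place of chloro would give a similar step on the core of compound 2.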